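Removing the triple bond from a phenyl-bearing compound

The source may hold more compounds than are shown below. What is called first, only, known or untested is meant among the compounds shown, and "the series" means these compounds.

So far, three compounds built on one shared core have been measured in a functional assay on K562 cells (Homo sapiens) for antiproliferative activity, with a stated time of 72 h; a lower number here means a stronger inhibitor, a higher number a weaker inhibitor. Compound 1 `CCCC#Cc1cc([C@@H]2O[C@H](CO)[C@@H](O)[C@H]2O)n2ncnc(N)c12`, with propyl on the triple-bonded carbon, gives 1100 nM. Compound 2 `CCCCC#Cc1cc([C@@H]2O[C@H](CO)[C@@H](O)[C@H]2O)n2ncnc(N)c12`, with butyl there, gives 2400 nM, and that change is modest: a 2.2-fold higher number from compound 1 to compound 2 (0.34 log units; beyond the scatter). Compound 3 `Nc1ncnn2c([C@@H]3O[C@H](CO)[C@@H](O)[C@H]3O)cc(C#Cc3ccccc3)c12`, with phenyl there, reads > 100000 nM, which is a limit of the assay and not a number. The steps to it are large, an at least 90-fold higher number from compound 1 to compound 3 (1.95 log units; beyond the scatter) and an at least 41-fold higher number from compound 2 to compound 3 (1.61 log units; beyond the scatter), so compound 3 stands as the weakest of the three.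

Compound 4 `Nc1ncnn2c([C@@H]3O[C@H](CO)[C@@H](O)[C@H]3O)cc(-c3ccccc3)c12` has phenyl in place of 2-phenylethynyl on an aromatic carbon. For the measured compounds named here, no measured step removes a triple bond, so none of them bears on this change directly. The nearest guide is the large phenyl step an at least 90-fold higher number from compound 1 to compound 3 (1.95 log units; beyond the scatter), and since compound 4 also carries a phenyl, it is expected to stay weak rather than return to the level of compound 1. A shift to a lower number is still possible, though it may be no more than a reading just inside the limit. The expected step is an at least 3.3-fold lower number from compound 3 to compound 4 (0.52 log units; beyond the scatter). For compound 4 the estimated value is 30000 nM, with an expected range of 3000 nM to 100000 nM.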

Compound 4, half-maximal inhibitory concentration: > 100000 nM
Compound 4: no number, only a limit (the forecaster's own chance of this, stated with the estimate: 50%); at least 3.3-fold (0.52 log units) between middle value and limit.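

In this assay compound 4 reads > 100000 nM, which is a limit of the assay and not a number. For the compounds shown here, the steps from the two chain-bearing compounds are large, an at least 41-fold higher number from compound 2 to compound 4 (1.61 log units; beyond the scatter) and an at least 90-fold higher number from compound 1 to compound 4 (1.95 log units; beyond the scatter), so a phenyl on this aromatic carbon stays out of the measured range with the triple bond in place and also without it, which the earlier compounds could not show. No size can be read for the step between compound 3 and compound 4, because both stand at the same reading: the limit of > 100000 nM in this assay, at which 2 of the 4 values shown sit.

The compounds shown leave open whether the loss follows the phenyl ring itself or some other difference from the chains, since none of them carries a propyl or butyl chain set directly on this aromatic carbon, without the triple bond. They also leave open where between the chains and phenyl the activity falls away, which a cyclopropyl or pyridyl group on the triple-bonded carbon, or a hydroxyl or amine at the end of the pent-1-yn-1-yl chain, could begin to show.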